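The compounds below may be only part of what the source reports. "The series", "measured", "known", "first", "only" and "open" are said of these compounds alone.

Compound 1 `O=C(Nc1cc(Sc2ncn[nH]2)c(O)c2ccccc12)c1cccc([N+](=O)[O-])c1`: 29.3%
Compound 2 `COc1ccc(/C=C/C(=O)Nc2cc(Sc3ncn[nH]3)c(O)c3ccccc23)cc1OC`: 31.7%
Compound 3 `COc1ccc(C(=O)Nc2cc(Sc3ncn[nH]3)c(O)c3ccccc23)cc1`: 30.8%

All three compounds share a core and differ only in the group carried on the carbonyl carbon of the amide. In an assay on isolated protein for inhibition of RAC-alpha serine/threonine-protein kinase (Homo sapiens), read by fluorescence, with a stated time of 30 min, tested at 10 uM (on this read-out lower numbers stand for less inhibition and higher numbers for more inhibition at the one concentration tested (going by the name of the read-out)), compound 3 stands second highest of the three numbers, with compound 2 a little above it and compound 1 a little below it, both gaps within the scatter, so nothing separates them. Going by the values given here, the one step of a single change that has been measured runs a number 1.5 percentage points higher from compound 1 to compound 3 (within the scatter), a step that lies within the scatter.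

Compound 4 `O=C(/C=C/c1ccc(Cl)cc1)Nc1cc(Sc2ncn[nH]2)c(O)c2ccccc12` is the next member. It differs from compound 3 in one place: 2-(4-chlorophenyl)ethenyl in place of 4-methoxyphenyl on a carbonyl carbon.

The step from compound 1 to compound 3 is the only measured one at the same position, and it was within the scatter. Compound 2, which also carries an ethenyl-linked aryl group on that carbonyl carbon, gives a value close to that of compound 3. On this basis the change to compound 4 is expected to bring no step beyond the scatter in this assay, and the expected step is a number 0.2 percentage points higher from compound 3 to compound 4 (within the scatter). Compound 4 is therefore estimated at 31%, with a range from 20% to 42%.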

Compound 4, a percentage reported as inhibition, at one concentration (the size of the read-out at that concentration, not a potency): 31.8%
For compound 4 the middle estimate is 0.8 percentage points below the measured one; the measured number falls inside the stated range.
By their numbers in this assay, from the lowest: compounds 1, 3, 2 and 4 (each within the scatter of the next).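

In this assay, going by these compounds alone, the first step that brings an ethenyl link onto this carbonyl carbon, with 2-(4-chlorophenyl)ethenyl in place of 4-methoxyphenyl, runs a number 1 percentage points higher from compound 3 to compound 4 (within the scatter). Keeping that link and placing 4-chlorophenyl in place of 3,4-dimethoxyphenyl runs a number 0.1 percentage points higher from compound 2 to compound 4 (within the scatter), while 2-(4-chlorophenyl)ethenyl in place of 3-nitrophenyl runs a number 2.5 percentage points higher from compound 1 to compound 4 (within the scatter), so at this position neither the change of aryl group nor the added double bond outside the aromatic rings separates compound 4 from the three earlier compounds. No supporting measurement is available to explain why these numbers stay so close together.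

The groups shown on this carbonyl carbon are all aryl or ethenyl-linked aryl groups, which leaves open whether an amine, a carboxylic acid or a longer saturated chain there would produce a step beyond the scatter. Also open, going by these compounds, is how these compounds would compare across a range of concentrations, as the read-out reports inhibition at a single concentration and gives no potency.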